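Replacing an ethyl amide with a 4-methylcyclohexyl amide

The source may report more compounds than this note shows. Statements on the series, on what has been measured and on what is new or still open speak of the compounds shown alone.

The series shares a bicyclic thiazole core bearing an alkyne. In an assay on HEK293 cells for positive allosteric modulation of metabotropic glutamate receptor 5 (Homo sapiens), read by FLIPR, with a stated time of 1 h (on this read-out lower numbers stand for an effect already at smaller amounts and higher numbers for an effect only at larger amounts of compound), compound 1 `O=C1NCCc2nc(C#Cc3ccccc3F)sc21` gives 1500 nM. Compound 2 `Cc1cccc(C#Cc2nc3c(s2)C(=O)NCC3)c1` reaches only the limit of this assay, > 10000 nM. Compound 3 `CCC(=O)N1CCc2nc(C#Cc3ccccc3)sc2C1`, which carries a propionyl group on the ring nitrogen, likewise reaches only a limit, > 10000 nM; it therefore stands at the limit of > 10000 nM in this assay, at which 2 of the 3 values shown sit, and no number places it relative to compound 1.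

Compound 4 `CC1CCC(C(=O)N2CCc3nc(C#Cc4ccccc4)sc3C2)CC1` differs from compound 3 in one place: 4-methylcyclohexyl in place of ethyl on a carbonyl carbon. The effect of this change is not documented by any pair of measured compounds here, so any expectation rests on the limit that compound 3 shows. Because compound 3 sits at > 10000 nM, the expected direction is toward a smaller number, though a further limit is nearly as likely as a measurable value. Compound 4 is expected to give 4000 nM, within 800 nM to 20000 nM. That corresponds to an expected step of an at least 2.5-fold lower number from compound 3 to compound 4 (0.39 log units; beyond the scatter).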

Compound 4, half-maximal effective concentration: 190 nM
For compound 4 the middle estimate is 21-fold (1.32 log units) above the measured one, and the stated range ends above it.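

This position, a carbonyl carbon whose other neighbour is an amide-type nitrogen in a ring, proved highly sensitive to the group it carries: in this assay, 4-methylcyclohexyl in place of ethyl gives an at least 52-fold lower number from compound 3 to compound 4 (1.72 log units; beyond the scatter). Among these compounds, this is the first step between measured compounds, and it turns a limit into a measurable value without adding any hydrogen-bond donor or acceptor. The value of compound 3 is a limit and not a number, so the step has no upper bound: the limit of > 10000 nM in this assay, at which 2 of the 4 values shown sit.

The compounds shown do not separate the contributions of the ring, its methyl and the added carbon. An unsubstituted cyclohexyl, an open hexyl chain or a ring bearing an amine in place of the methyl would address this.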